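The compounds below may be only part of what the source reports. "The series", "measured", "known", "first", "only" and "open" are said of these compounds alone.

Measured so far:
Compound 1, `CCCS(=O)(=O)Nc1ccc(F)c(C(=O)c2n[nH]c3ncc(-c4ccc(N)cc4)cc23)c1F`: 0.1%
Compound 2, `CCCS(=O)(=O)Nc1ccc(F)c(C(=O)c2n[nH]c3ncc(-c4ccc(Cl)c(C(F)(F)F)c4)cc23)c1F`: 15%
Compound 3, `CCCS(=O)(=O)Nc1ccc(F)c(C(=O)c2n[nH]c3ncc(-c4ccc(S(=O)(=O)NC(C)=O)cc4)cc23)c1F`: 0.35%

In an assay for binding affinity to dual specificity mitogen-activated protein kinase kinase 4 (Homo sapiens), read by KINOMEscan, tested at 100 nM (a lower number here means a stronger effect, a higher number a weaker effect of the compound at the concentration tested), compound 3 holds the second highest of the three numbers. Its nearest neighbour is compound 1, with a number 0.3 percentage points higher from compound 1 to compound 3 (within the scatter), while compound 2 lies far from it, as a number 14.9 percentage points higher from compound 1 to compound 2 (beyond the scatter) shows. Compound 4, `CCCS(=O)(=O)Nc1ccc(F)c(C(=O)c2n[nH]c3ncc(-c4ccc(C(N)=O)cc4)cc23)c1F`, differs from compound 3 in one place: carbamoyl in place of acetylsulfamoyl on an aromatic carbon. Among the compounds with values here, the step that bears on this is the one from compound 1 to compound 3, where a group with one hydrogen-bond donor replaced amino at the same aromatic carbon without moving the number beyond the scatter; the larger shift seen from compound 1 to compound 2 came from a group of a different kind. Compound 4 is therefore expected to show a number 0.1 percentage points higher from compound 3 to compound 4 (within the scatter), with no movement beyond the scatter. For compound 4 the estimate is 0.4%, between 0.05% and 4%.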

Compound 4, a percentage reported as activity, at one concentration (the size of the read-out at that concentration, not a potency): 0.15%
Compound 4: the middle estimate sits 0.3 percentage points above what was measured, within the range that was stated.
By their numbers in this assay, from the lowest: compounds 1, 4 and 3 (each within the scatter of the next); then compound 2.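

In this assay, the smaller carbamoyl stands in for acetylsulfamoyl with a number 0.2 percentage points lower from compound 3 to compound 4 (within the scatter), and in place of amino with a number 0.1 percentage points higher from compound 1 to compound 4 (within the scatter), so these three groups at this aromatic carbon cannot be told apart. Carbamoyl in the 4-carbamoylphenyl group also separates from the 4-chloro-3-(trifluoromethyl)phenyl group, with a number 14.9 percentage points lower from compound 2 to compound 4 (beyond the scatter). No measurement here explains these results. From the compounds shown here alone, whether a carboxylic acid or a dimethylamino group at this carbon would also stay within the scatter remains open. So does whether the chlorine or the trifluoromethyl accounts for the step involving compound 2.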